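Tolerance on Vero cells after a phenyl substituent change

The compounds below may be only part of what the source reports. "The series", "measured", "known", "first", "only" and "open" are said of these compounds alone.

Compound 1 `COC(=O)c1cc(-c2cccc(NC(=O)c3ccc(/C=C/C(=O)c4ccc(C)cc4)cc3)c2)on1` was assessed in an ADME assay on Vero cells (Chlorocebus sabaeus) for cytotoxicity, read by MTT assay, with a stated time of 72 h; a lower number here means that less compound is tolerated, a higher number that more compound is tolerated. In this assay compound 1 gives > 80 ug/mL, which is a limit of the assay and not a number, sitting at the limit of > 80 ug/mL in this assay, at which 1 of the 2 values shown sits. A second compound, compound 2 `CCCOc1ccc(C(=O)/C=C/c2ccc(C(=O)O)cc2)cc1`, differs from compound 1 at more than one place. In this assay compound 2 gives < 10 ug/mL, again a limit and not a number, at the limit of < 10 ug/mL in this assay, at which 1 of the 2 values shown sits. Going by the values given here, no single-place step joins compound 1 and compound 2, so their two values show only that each sits at a limit of the assay. The compound not yet measured is compound 3 `COC(=O)c1cc(-c2cccc(NC(=O)c3ccc(/C=C/C(=O)c4cccc([N+](=O)[O-])c4)cc3)c2)on1`. It differs from compound 1 by 3-nitrophenyl in place of 4-methylphenyl on a carbonyl carbon. Given that compound 1 reaches > 80 ug/mL, the step of a number no higher from compound 1 to compound 3 (the limit leaves the size open) is expected to stay within the usual scatter. Compound 3 is estimated at 80 ug/mL, between 40 ug/mL and 160 ug/mL.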

Compound 3, half-maximal cytotoxic concentration: > 40 ug/mL
Compound 3: a limit, no number; the forecaster's own chance of this, stated with the estimate: 60%; the middle value lies beyond the limit too.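

In this assay, going by these compounds alone, compound 1 and compound 3 each give a limit and not a number, so no step between them can be read. The compounds shown leave open whether 3-nitrophenyl in place of 4-methylphenyl on a carbonyl carbon changes tolerance at all, and by how much.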